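Anilino series: trifluoromethyl on the phenyl of compound 3

A few compounds are considered here, and "the series" means these few. Any claim that something is new, unique, unknown or untested is made for them only; others in the source may bear on it.

Compound 3 `O=C1C(Nc2ccccc2)=CC(=O)c2c1nc1n2[C@H]2OC[C@@H](O)[C@H]2OC1` carries a phenyl on the amine nitrogen of the shared core. In a functional assay on HeLa cells (Homo sapiens) for inhibition, read by sulforhodamine B assay (on this read-out lower numbers stand for stronger inhibition and higher numbers for weaker inhibition), compound 3 gives only a limit, > 8000 nM. Compound 1 `O=C1C(NC2CCCC2)=CC(=O)c2c1nc1n2[C@H]2OC[C@@H](O)[C@H]2OC1`, with a cyclopentyl on that nitrogen, likewise gives only a limit in this assay, > 16000 nM. Compound 2 `O=C1C(NC2CCCCC2)=CC(=O)c2c1nc1n2[C@H]2OC[C@@H](O)[C@H]2OC1`, with a cyclohexyl, also gives only a limit in this assay, > 16000 nM. Hence a step that the two limits leave unreadable from compound 1 to compound 2, a step that the two limits leave unreadable from compound 1 to compound 3 and a step that the two limits leave unreadable from compound 2 to compound 3 cannot be sized; the values sit at the limit of > 16000 nM in this assay, at which 2 of the 3 values shown sit, and (the limit of > 8000 nM in this assay, at which 1 of the 3 values shown sits). Compound 4 `O=C1C(Nc2ccc(C(F)(F)F)cc2)=CC(=O)c2c1nc1n2[C@H]2OC[C@@H](O)[C@H]2OC1` differs from compound 3 by trifluoromethyl in place of hydrogen on an aromatic carbon. Among the compounds with values here, no measured step bears on this change, so nothing beyond the scatter is expected of a step that the limit leaves unreadable from compound 3 to compound 4. Compound 4 is therefore estimated at 10000 nM in this assay, between 2000 nM and 40000 nM, most likely reported again as a limit.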

Compound 4, half-maximal inhibitory concentration: 8920 nM
Estimate against measurement, compound 4: 1.1-fold (0.05 log units) above; low and high end bracket the measured number.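

In this assay compound 4, with 4-(trifluoromethyl)phenyl on the amine nitrogen, is the only compound shown that gives a number rather than a limit, 8920 nM. Compound 3 gives only a limit, > 8000 nM, so the step to compound 4 cannot be read. The readable steps are an at least 1.7-fold lower number from compound 2 to compound 4 (0.25 log units; that floor lies within the scatter) and an at least 1.7-fold lower number from compound 1 to compound 4 (0.25 log units; that floor lies within the scatter), so neither establishes a gain.

The compounds shown leave open how a nitrile, a chlorine or a carboxylic acid on that aromatic carbon would read in this assay. Going by these compounds, the true size of the trifluoromethyl step also stays open.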